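This account rests on a few compounds, and the source may have more. Where it says the series, first, only, none or still open, it means among the compounds named here.

The measured compounds and their values:

Compound 1 `COc1cc2c(Oc3c(F)cc(NC(=O)NN4C(=O)CSC4c4c(F)cccc4F)cc3F)ccnc2cc1OCCCN1CCC(C)CC1` gives 220 nM in a functional assay on HT-29 cells (Homo sapiens) for antiproliferative activity, read by MTT assay, with a stated time of 72 h; a lower number here means a stronger inhibitor, a higher number a weaker inhibitor.
Compound 2 `COc1cc2c(Oc3c(F)cc(NC(=O)NN4C(=O)CSC4c4c(F)cccc4F)cc3F)ccnc2cc1OCCCN1CCN(C)CC1` gives 150 nM in this assay.

Compound 2 holds the lowest of the two numbers in this assay, but its nearest neighbour is compound 1, and the step of a 1.5-fold lower number from compound 1 to compound 2 (0.17 log units; within the scatter) lies within the scatter, so the two compounds cannot be told apart on these data.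

Compound 3 `COc1cc2c(Oc3c(F)cc(NC(=O)NN4C(=O)CSC4c4c(F)cccc4F)cc3F)ccnc2cc1OCCCN1C[C@H]2CCCC[C@H]2C1` differs from compound 2 in one place: a group of 9 heavy atoms (8 carbon, 1 nitrogen; one five-membered non-aromatic ring with 1 hetero atom, one six-membered non-aromatic ring of carbon only) in place of a group of 7 heavy atoms (5 carbon, 2 nitrogen; one six-membered non-aromatic ring with 2 hetero atoms), on a saturated chain carbon, three bonds along the chain from an oxygen on an aromatic ring. Within the data shown here, the only measured step that bears on this position is the exchange of the terminal saturated amine between compound 1 and compound 2, a 1.5-fold lower number from compound 1 to compound 2 (0.17 log units; within the scatter), which did not move the number beyond the scatter. The change to compound 3 is a larger one, bringing a bicyclic group with two defined stereocentres, and nothing in the measured pairs covers such a group, so the expectation rests on a single step of small size.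

On that basis compound 3 is expected to stay close to compound 2, with the step of a 1.2-fold higher number from compound 2 to compound 3 (0.08 log units; within the scatter) in this assay expected to be small. The estimate for compound 3 is 180 nM, with a range from 70 nM to 450 nM.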

Compound 3, half-maximal inhibitory concentration: 470 nM
Compound 3: the middle estimate sits 2.6-fold (0.42 log units) below what was measured; the measured number lies above the stated range.
By their numbers in this assay, from the lowest: compounds 2 and 1 (each within the scatter of the next); then compound 3.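

In this assay, the terminal group on a saturated chain carbon, three bonds along the chain from an oxygen on an aromatic ring, now proves able to move the number beyond the scatter, which the exchange of 4-methylpiperidin-1-yl for 4-methylpiperazin-1-yl had not shown. The fused two-ring group gives a 3.1-fold higher number from compound 2 to compound 3 (0.50 log units; beyond the scatter) and, measured against the other single-ring amine, a 2.1-fold higher number from compound 1 to compound 3 (0.33 log units; beyond the scatter), so both single-ring groups stand apart from it in the same direction, though each step is only modest. The position therefore accepts this larger group with a measurable but limited rise in the number, and nothing available here explains that rise.

The compounds shown do not separate the second ring, the larger group and the two defined stereocentres of compound 3 from one another, and the opposite stereoisomers of that group would bear directly on the last of these. Simpler amines such as pyrrolidin-1-yl or morpholin-4-yl on the same chain would show whether the five-membered ring alone carries the rise or whether the fused six-membered carbon ring is needed.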